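Working notes: from compound 3 to compound 4

The source may report more compounds than this note shows. Statements on the series, on what has been measured and on what is new or still open speak of the compounds shown alone.

Measured in an ADME assay on microsomes from liver (Mus musculus, strain CD-1) for metabolic stability, read by LC-MS, tested at 2 uM (a lower number here means that the compound disappears faster, a higher number that the compound lasts longer), so far:
- compound 1 (`CNC(=O)c1ccncc1Nc1cc(-c2ccc3ccn(C)c3c2)c2nccnc2c1`) gives 0.45 h
- compound 2 (`CN1CCC(NC(=O)c2ccncc2Nc2cc(-c3ccc4ccn(C)c4c3)c3nccnc3c2)CC1`) gives > 1 h as a limit of the assay
- compound 3 (`CC(=O)N1CCC(NC(=O)c2ccncc2Nc2cc(-c3ccc4ccn(C)c4c3)c3nccnc3c2)CC1`) gives 0.117 h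

Of the two values that are true numbers, compound 3 sits lowest at 0.117 h with compound 1 as its nearest neighbour.

The change to compound 4 (`CC(=O)N1CCCC(NC(=O)c2ccncc2Nc2cc(-c3ccc4ccn(C)c4c3)c3nccnc3c2)C1`) is 1-acetylpiperidin-3-yl in place of 1-acetylpiperidin-4-yl on an amide-type nitrogen and it puts 1-acetylpiperidin-3-yl in place of 1-acetylpiperidin-4-yl on an amide-type nitrogen. The two have the same atoms, joined differently.

The closest measured evidence is a 3.8-fold lower number from compound 1 to compound 3 (0.59 log units; beyond the scatter) for a change of group on that same nitrogen. Also relevant is an at least 8.5-fold lower number from compound 2 to compound 3 (0.93 log units; beyond the scatter) for acetyl in place of methyl on an amine nitrogen in a ring, a step that rests on a limit. Within the data shown here, both exchange one group for another, and no measured pair moves the attachment point within the piperidine ring. Compound 4 keeps the acetyl group of compound 3, so a small step is expected, with a slight lean upward at most.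

The expected step is a 1.2-fold higher number from compound 3 to compound 4 (0.08 log units; within the scatter) and no shift beyond the scatter is expected. For compound 4 the estimated half-life is 0.14 h with an expected range from 0.06 h to 0.35 h in this assay as the working figure.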

Compound 4, half-life: 0.4 h
Compound 4: the middle estimate sits 2.9-fold (0.46 log units) below what was measured; the measured number lies above the stated range.
By their numbers in this assay, from the lowest: compound 3; then compounds 4 and 1 (each within the scatter of the next). At a limit, above all of these: compound 2.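

In this assay, 1-acetylpiperidin-3-yl in place of 1-acetylpiperidin-4-yl on an amide-type nitrogen gives a 3.4-fold higher number from compound 3 to compound 4 (0.53 log units; beyond the scatter), so with the acetyl kept and the atoms unchanged, the point of attachment alone moves the half-life beyond the scatter. The drop seen for the 1-acetylpiperidin-4-yl group, a 3.8-fold lower number from compound 1 to compound 3 (0.59 log units; beyond the scatter), therefore does not extend to every acetylated piperidine, since the 1-acetylpiperidin-3-yl group gives a 1.1-fold lower number from compound 1 to compound 4 (0.05 log units; within the scatter). The 1-methylpiperidin-4-yl group still stands apart, with an at least 2.5-fold lower number from compound 2 to compound 4 (0.39 log units; beyond the scatter), and that step rests on a limit: the limit of > 1 h in this assay, at which 1 of the 4 values shown sits.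

From the compounds shown here alone, it remains open whether the gain from moving the attachment point belongs to the acetylated ring alone or would also appear with 1-methylpiperidin-3-yl on the same nitrogen. Also open, going by these compounds, are how far compound 2 lies past its limit, how a smaller ring such as 1-acetylpyrrolidin-3-yl would compare, and whether a free piperidin-3-yl amine would follow compound 4 or compound 2.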